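The compounds below may be only part of what the source reports. "The series", "measured", "known", "first", "only" and "open" are said of these compounds alone.

Values so far in a functional assay on MCF7 cells (Homo sapiens) for cytotoxicity, read by sulforhodamine B assay, with a stated time of 48 h (a lower number here means a stronger inhibitor, a higher number a weaker inhibitor), are as follows.
- Compound 1 `CC1(C)CNC(=O)c2cc(-c3ccc([N+](=O)[O-])cc3)n(-c3ccc(Cl)cc3)c2C1` gives 51700 nM as a number
- Compound 2 `CC1(C)CNC(=O)c2cc(-c3ccc([N+](=O)[O-])cc3)n(-c3ccc(Br)cc3)c2C1` gives > 100000 nM which is a limit
- Compound 3 `CC1(C)CNC(=O)c2cc3n(c2C1)CCc1ccccc1-3` gives > 100000 nM which is a limit

Compound 3 stands at > 100000 nM in this assay and this is a limit and not a number. It is one case of the limit of > 100000 nM in this assay, at which 2 of the 3 values shown sit, in this small set.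

Compound 4 `CC1(C)CNC(=O)c2cc3n(c2C1)CCc1cc(Br)ccc1-3` has one change from compound 3, with bromo in place of hydrogen on an aromatic carbon in the shared core.

Among the measured compounds shown here, the only measured step that touches a halogen is an at least 1.9-fold higher number from compound 1 to compound 2 (0.28 log units; that floor lies within the scatter) and it replaces chloro with bromo, so it bears only loosely on adding bromo in place of hydrogen. For the measured compounds named here, no measured step adds a halogen to the core of compound 3. A step beyond the scatter is therefore not expected, and compound 4 is expected to stay close to the limit.

The expected step is an at least 1.1-fold lower number from compound 3 to compound 4 (0.04 log units; that floor lies within the scatter) in size.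

For compound 4 the estimated value is 90000 nM with an expected range from 35000 nM to 150000 nM in this assay.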

Compound 4, half-maximal inhibitory concentration: 43200 nM
Compound 4: the middle estimate sits 2.1-fold (0.32 log units) above what was measured; low and high end bracket the measured number.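

In this assay, bromo in place of hydrogen on the aromatic carbon of the six-membered ring, meta to a fused ring and para to a fused ring, gives an at least 2.3-fold lower number from compound 3 to compound 4 (0.36 log units; beyond the scatter). This is the first listed step that adds a halogen to the core of compound 3, whereas the earlier halogen step only exchanged chloro for bromo and gave an at least 1.9-fold higher number from compound 1 to compound 2 (0.28 log units; that floor lies within the scatter). The true size of the new step stays unknown, and only a floor can be read, because compound 3 rests on a limit of the assay: the limit of > 100000 nM in this assay, at which 2 of the 4 values shown sit.

Open, going by these compounds, is whether fluoro, methoxy or an amine on the same aromatic carbon would shift the number as bromo does. Also open, on these data alone, is whether bromo on another carbon of that ring would give a similar step.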